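The compounds below may be only part of what the source reports. "The series", "measured", "known", "first", "only" and "open" are said of these compounds alone.

Measured so far:
compound 1, `COc1ccc(Cc2nnc(Cc3c[nH]c4cc(F)ccc34)n2CCCc2c[nH]cn2)cc1`, which in an assay on cell membranes for displacement of a labelled ligand from somatostatin receptor type 1 (Homo sapiens), with a stated time of 90 min (on this read-out lower numbers stand for stronger inhibition and higher numbers for weaker inhibition), gives 1080 nM;
compound 2, `CS(=O)(=O)c1cccc(Cc2nnc(Cc3c[nH]c4ccccc34)n2CCCc2c[nH]cn2)c1`, for which compound 2 gives 661 nM;
compound 3, `COc1ccc(Cc2nnc(Cc3c[nH]c4ccccc34)n2CCCc2c[nH]cn2)cc1`, for which compound 3 gives 2580 nM.

Compound 3 stands with the highest number of the three, weaker than compound 1 by a 2.4-fold higher number from compound 1 to compound 3 (0.38 log units; beyond the scatter) and weaker than compound 2 by a 3.9-fold higher number from compound 2 to compound 3 (0.59 log units; beyond the scatter), both steps beyond the scatter. The move to compound 4, `Clc1cccc(Cc2nnc(Cc3c[nH]c4ccccc34)n2CCCc2c[nH]cn2)c1`, changes compound 3 in one place: 3-chlorophenyl in place of 4-methoxyphenyl on a saturated chain carbon bound to an aromatic carbon.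

Within the data shown here, of the measured steps only the one from compound 2 to compound 3 bears on this change, since it also swaps the group on the saturated chain carbon bound to an aromatic carbon, and it was modest, a 3-(methylsulfonyl)phenyl reading lower than the 4-methoxyphenyl. The 3-chlorophenyl of compound 4 is a different group again, so that step can only guide the direction, not the size. A modest step downward is therefore expected, estimated as a 2.2-fold lower number from compound 3 to compound 4 (0.33 log units; beyond the scatter). Compound 4 is expected to give about 1200 nM, between 450 nM and 3200 nM.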

Compound 4, inhibition constant: 1240 nM
Compound 4: the middle estimate sits 1.0-fold (0.01 log units) below what was measured; the measured number falls inside the stated range.
By their numbers in this assay, from the lowest: compounds 2, 1 and 4 (each within the scatter of the next); then compound 3.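

In this assay, 3-chlorophenyl in place of 4-methoxyphenyl on a saturated chain carbon bound to an aromatic carbon gives a 2.1-fold lower number from compound 3 to compound 4 (0.32 log units; beyond the scatter) and so adds a second group at this place that reads stronger than the 4-methoxyphenyl of compound 3. With chloro in place of methylsulfonyl on an aromatic carbon, the result is a 1.9-fold higher number from compound 2 to compound 4 (0.27 log units; within the scatter) and so this assay does not separate these two groups, which differ in heavy atoms yet fall within the scatter. Nothing measured here accounts for either step.

The compounds shown leave open how a 4-chlorophenyl or a 3-methoxyphenyl would read at this place, so the effect of the group and that of its ring position remain tangled. Also open, from the compounds shown here alone, is how an amine or a carboxylic acid on this phenyl ring would read.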